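Shortening the acyl chain from compound 2 to compound 4

The source may hold more compounds than are shown below. What is called first, only, known or untested is meant among the compounds shown, and "the series" means these compounds.

Compound 2, `CC(NC(=O)CN)C(=O)N(C)c1ccc(Cl)cc1C(=O)c1ccccc1Cl`, is the most active of the three compounds measured in a functional assay on the whole organism for antagonist activity, with Mus musculus as the target (on this read-out lower numbers stand for an effect already at smaller amounts and higher numbers for an effect only at larger amounts of compound), where compound 2 gives 0.47 mg/kg. Compound 3, `CCCCCC(=O)NCC(=O)N(C)c1ccc(Cl)cc1C(=O)c1ccccc1Cl`, gives 1.9 mg/kg in this assay, and compound 1, `CN(C)CC(=O)NCC(=O)N(C)c1ccc(Cl)cc1C(=O)c1ccccc1Cl`, gives 2.6 mg/kg; the values of compound 1 and compound 3 lie within the scatter of each other.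

Compound 4, `CCC(=O)NCC(=O)N(C)c1ccc(Cl)cc1C(=O)c1ccccc1Cl`, has not yet been tested. It differs from compound 2 in one place: (propanoylamino)methyl in place of 1-(((aminomethyl)carbonyl)amino)ethyl on a carbonyl carbon

For the measured compounds named here, two measured steps bear on this change. The step from compound 2 to compound 3 already removes the aminomethyl amide and the extra methyl, replacing them with a longer acyl chain, and gives a 4.0-fold higher number from compound 2 to compound 3 (0.61 log units; beyond the scatter). The step from compound 1 to compound 2 shows the same amide-bearing chain entering, with a 5.5-fold lower number from compound 1 to compound 2 (0.74 log units; beyond the scatter). The chain entering compound 4 is a shorter relative of the chain in compound 3, and compounds 1 and 3 show that two quite different chains without that inner amide land close together.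

A modest rise is therefore expected, a 3.8-fold higher number from compound 2 to compound 4 (0.58 log units; beyond the scatter), placing compound 4 near compound 3. The estimate for compound 4 in this assay is 1.8 mg/kg, with a range of 0.7 mg/kg to 4.5 mg/kg.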

Compound 4, dose for half-maximal effect: 1.4 mg/kg
Compound 4: middle estimate off by 1.3-fold (0.11 log units), on the high side, and the stated range covers the measured number.
By their numbers in this assay, from the lowest: compound 2; then compounds 4, 3 and 1 (each within the scatter of the next).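

Compound 4 shows that the gain seen in compound 2 does not survive in a short, plain acyl chain: in this assay there is a 3.0-fold higher number from compound 2 to compound 4 (0.47 log units; beyond the scatter) on going to (propanoylamino)methyl. Chain length alone makes no readable difference here, since there is a 1.4-fold lower number from compound 3 to compound 4 (0.13 log units; within the scatter) and also a 1.9-fold lower number from compound 1 to compound 4 (0.27 log units; within the scatter) in this assay, so methyl, butyl and dimethylamino on the saturated chain carbon bound to a carbonyl carbon cannot be told apart, and among the four compounds only compound 2 stands clear of the others. No measurement at hand explains why the numbers fall this way.

The step from compound 2 to compound 4 changes the aminomethyl amide and the extra methyl of the 1-(((aminomethyl)carbonyl)amino)ethyl group together, so these compounds cannot say which of the two carries the lower number of compound 2. Going by these compounds, it also remains open how a hydroxyl or a carboxylic acid in place of that aminomethyl group would read in this assay on this shared core.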